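Swapping a Pyridine for Phenyl in a Dopamine D4 Series

The source may report more compounds than this note shows. Statements on the series, on what has been measured and on what is new or still open speak of the compounds shown alone.

Of the compounds shown here, two from this series have been measured in an assay on cells for agonist activity at D(4) dopamine receptor (Homo sapiens), read by luminescence and beta-arrestin recruitment, with a stated time of 90 min; a higher number here means a larger maximal response, a lower number a smaller maximal response. Compound 1, `O=C(CN1CCN(c2ccccn2)CC1)Nc1cccnc1`, gives 19%, a small maximal response in this assay. Compound 2, `Cc1ccc(C2CCN(CC(=O)Nc3cccc(C)c3)CC2)nc1`, is reported in this assay only as "not active" (no number reported), so no single number describes where it stands.

Compound 3, `Cc1ccc(C2CCN(CC(=O)Nc3cccc(C)c3)CC2)cc1`, has not yet been measured. It differs from compound 2 in one place: 4-methylphenyl in place of 5-methylpyridin-2-yl on a saturated ring carbon.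

Within the data shown here, no measured pair in this set isolates this particular change, so its effect on maximal response is unknown. Given that compound 2 produced no reportable activity, the working expectation is that compound 3 also shows little or no maximal response in this assay, without a step beyond the usual scatter. Compound 3 is therefore estimated at 10%, with a range of 0% to 25%.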

Compound 3, largest response reached (Emax), in percent of the reference or control that the assay uses: "not active" (no number reported)
No number was reported for compound 3; there is nothing to compare the estimate with.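

In this assay compound 2 gives "not active" (no number reported) and compound 3 gives "not active" (no number reported), so no step can be read for 4-methylphenyl in place of 5-methylpyridin-2-yl. The compounds shown leave open whether this swap changes the maximal response at all. No measured evidence bears on these results.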